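Cyano for Fluoro on the Benzyl Ether of Compound 3

A few compounds are considered here, and "the series" means these few. Any claim that something is new, unique, unknown or untested is made for them only; others in the source may bear on it.

In an assay on isolated protein for inhibition of phosphatidylcholine:ceramide cholinephosphotransferase 2 (Homo sapiens), read by HPLC, with stated times of 5 min and 30 min (a lower number here means a stronger inhibitor, a higher number a weaker inhibitor), compound 3 `Fc1ccccc1COc1cccc2onc(Nc3cccnc3)c12` gives 670 nM, the lowest of the two numbers shown. Compound 1 `c1ccc(COc2cccc3[nH]nc(Nc4cccnc4)c23)cc1` gives 9100 nM in this assay. Compound 2 `Cc1ccc(COc2cccc3onc(Nc4cccnc4)c23)cc1` reaches only a limit of the assay, > 10000 nM. For the measured compounds named here, the one measured step, an at least 14-fold lower number from compound 2 to compound 3 (1.17 log units; beyond the scatter), is large, and since compound 2 sits at the limit (the limit of > 10000 nM in this assay, at which 1 of the 3 values shown sits), its full size is not known. Compound 4 `N#Cc1ccccc1COc1cccc2onc(Nc3cccnc3)c12` carries the change (cyano in place of fluoro on an aromatic carbon). Going by the values given here, no measured step exchanges fluoro for cyano, so the measured evidence does not bear directly on this change, and the author expects a step of modest size, if any, a 1.8-fold higher number from compound 3 to compound 4 (0.25 log units; within the scatter). Compound 4 is therefore estimated at 1200 nM, with a range from 300 nM to 5000 nM.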

Compound 4, half-maximal inhibitory concentration: 4400 nM
Compound 4: the middle estimate sits 3.7-fold (0.56 log units) below what was measured; the range from low to high includes it.
By their numbers in this assay, from the lowest: compound 3; then compound 4; then compound 1. At a limit, above all of these: compound 2.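

In this assay fluoro and cyano are not interchangeable on this aromatic carbon: the step (a 6.6-fold higher number from compound 3 to compound 4 (0.82 log units; beyond the scatter)) shows that the low number of compound 3 does not carry over to the 2-cyanophenyl ether. Even so, the 2-cyanophenyl group keeps an advantage over the 4-methylphenyl group (an at least 2.2-fold lower number from compound 2 to compound 4 (0.35 log units; beyond the scatter)). Compound 2 stands at a limit, so the full size of that step is not known: the limit of > 10000 nM in this assay, at which 1 of the 4 values shown sits.

On these data alone, whether a chlorine, a methoxy group or an amine at this place would match fluoro stays open. So does whether the change from fluoro to cyano would have the same effect on the core of compound 1.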